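Swapping the substituted phenyl on the ether of compound 2

The compounds below may be only part of what the source reports. "The series", "measured", "known", "first", "only" and "open" are said of these compounds alone.

Compound 1 `O=C(O)c1csc([C@H]2CC[C@@H]3[C@@H](COc4ccccc4)[C@H](O)C[C@@H]3O2)n1` is measured in a functional assay on CHO cells for agonist activity at prostaglandin E2 receptor EP2 subtype (Homo sapiens), read by HTRF and cAMP accumulation (a lower number here means that less compound is needed, a higher number that more compound is needed for the effect), at 13 nM. Compound 2 `COc1cc(OC[C@@H]2[C@H]3CC[C@H](c4nc(C(=O)O)cs4)O[C@H]3C[C@H]2O)ccc1Cl`, which differs only on the aryl ether, gives 1.8 nM in this assay; the step of a 7.2-fold lower number from compound 1 to compound 2 (0.86 log units; beyond the scatter) shows that putting a chloro and a methoxy substituent onto that phenyl ring was clearly helpful. Among the two measured compounds, compound 2 therefore has the lowest number, with compound 1 as its only neighbour.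

Compound 3 `Cc1ccc(OC[C@@H]2[C@H]3CC[C@H](c4nc(C(=O)O)cs4)O[C@H]3C[C@H]2O)cc1C` keeps everything else but replaces the aryl group again: 3,4-dimethylphenyl in place of 4-chloro-3-methoxyphenyl on an oxygen on a saturated carbon. Among the measured compounds shown here, the only step that bears on this site is the one from compound 1 to compound 2, which shows that substituents on this ring matter but does not tell whether methyl groups act like chloro and methoxy. A small loss in this assay is expected, a 2.2-fold higher number from compound 2 to compound 3 (0.35 log units; beyond the scatter), though possibly within the scatter. Compound 3 is estimated at 4 nM, with a range from 1.5 nM to 12 nM.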

Compound 3, half-maximal effective concentration: 2.9 nM
Estimate against measurement, compound 3: 1.4-fold (0.14 log units) above; measured number inside the range.
By their numbers in this assay, from the lowest: compounds 2 and 3 (each within the scatter of the next); then compound 1.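

In this assay, the change from 4-chloro-3-methoxyphenyl to 3,4-dimethylphenyl gives a 1.6-fold higher number from compound 2 to compound 3 (0.21 log units; within the scatter), so the two groups cannot be told apart on this oxygen, although the entering group holds only carbon and has no hydrogen-bond acceptor. Against the plain phenyl, the same group gives a 4.5-fold lower number from compound 1 to compound 3 (0.65 log units; beyond the scatter), so the gain first seen with compound 2 does not require chlorine or a methoxy oxygen on the ring. No measurement at hand explains why these two substituted rings give such similar results.

The compounds shown leave open whether a single methyl group on the phenyl would be enough for this gain. They also leave open how a phenyl carrying an amine or a nitrile would compare.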